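The compounds below may be only part of what the source reports. "The series", "measured", "known", "first", "only" and "open" are said of these compounds alone.

Of the compounds shown here, three have been measured in an ADME assay on MT4 cells (Homo sapiens) for cytotoxicity, read by MTT assay; on this read-out higher numbers stand for lower toxicity in this test and lower numbers for higher toxicity in this test. Compound 1 `O=C1c2ccccc2C(=O)N1CCOC(=S)N(C(=O)c1cccnc1Cl)c1ccc(Br)cc1` gives > 100000 nM, which is a limit of the assay rather than a number; (the limit of > 100000 nM in this assay, at which 1 of the 3 values shown sits). Compound 2 `O=C1c2ccccc2C(=O)N1CCOC(=S)N(C(=O)c1ccc(Cl)c(Cl)c1)c1ccccc1` gives 52000 nM in this assay. Compound 3 `O=C1c2ccccc2C(=O)N1CCOC(=S)N(C(=O)c1cc(F)ccc1F)c1ccc(Cl)cc1` gives 54000 nM in this assay, which lies within the scatter of the value of compound 2, so no order can be set between the two. Compound 4 `O=C1c2ccccc2C(=O)N1CCOC(=S)N(C(=O)c1ccc([N+](=O)[O-])cc1Cl)c1ccc(Cl)cc1` has not yet been measured in this assay. It differs from compound 3 in one place: 2-chloro-4-nitrophenyl in place of 2,5-difluorophenyl on a carbonyl carbon. Going by the values given here, no step between two measured compounds matches this change, so nothing measured tells how it acts on toxicity. Given that the two numbers known, for compound 2 with 52000 nM and compound 3 with 54000 nM, lie so close, the step from compound 3 to compound 4 is expected to stay within the scatter, a 1.0-fold higher number from compound 3 to compound 4 (0.01 log units; within the scatter). Compound 4 is therefore estimated at 55000 nM in this assay, with a range from 25000 nM to 120000 nM.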

Compound 4, half-maximal cytotoxic concentration: 19000 nM
The estimate for compound 4 lay 2.9-fold (0.46 log units) above the measured number; measured number below the stated range.
By their numbers in this assay, from the lowest: compound 4; then compounds 2 and 3 (each within the scatter of the next). At a limit, above all of these: compound 1.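

The group on the carbonyl carbon, whose other neighbour is an amide-type nitrogen, can move the read-out: in this assay, 2-chloro-4-nitrophenyl in place of 2,5-difluorophenyl gives a 2.8-fold lower number from compound 3 to compound 4 (0.45 log units; beyond the scatter), a modest step towards higher toxicity in this test. Going by these compounds alone, this pair is the first to differ in one place, so it gives the first reading of a single change. Nothing measured here bears on why the step occurs.

It remains open whether the nitro group, the chlorine or the loss of the two fluorines carries the step, as the compounds shown do not separate them. Also open, from the compounds shown here alone, is how an amine or a carboxylic acid on this ring would read in this assay.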